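Chain-length variation of a hydroxycarbamoyl side chain on a shared core

The source may hold more compounds than are shown below. What is called first, only, known or untested is meant among the compounds shown, and "the series" means these compounds.

Measured so far:
- compound 1 `Nc1ncnc2c1c(-c1cnc3[nH]ccc3c1)nn2CCCCCCC(=O)NO`: 22000 nM
- compound 2 `Nc1nc2cc(-c3nn(CCCC(=O)NO)c4ncnc(N)c34)ccc2o1`: > 150000 nM
- compound 3 `Nc1nc2cc(-c3nn(CCCCCCC(=O)NO)c4ncnc(N)c34)ccc2o1`: 6410 nM

In a functional assay on HeLa cells (Homo sapiens) for inhibition, read by MTT assay, with a stated time of 72 h (on this read-out lower numbers stand for stronger inhibition and higher numbers for weaker inhibition), compound 1 gives 22000 nM, the highest of the two numbers recorded. Its nearest neighbour is compound 3, a step of a 3.4-fold lower number from compound 1 to compound 3 (0.54 log units; beyond the scatter), which exchanges one ring pair for another on an aromatic carbon while keeping the side chain intact. Compound 2 yields only a limit in this assay, > 150000 nM (the limit of > 150000 nM in this assay, at which 1 of the 3 values shown sits). Among the measured compounds shown here, the comparison of compound 2 with compound 3 is the one chain-length step available: an at least 23-fold lower number from compound 2 to compound 3 (1.36 log units; beyond the scatter), so the longer chain carries a markedly lower number.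

Compound 4 `Nc1ncnc2c1c(-c1cnc3[nH]ccc3c1)nn2CCCCC(=O)NO` has not been measured. It differs from compound 1 by hydroxycarbamoyl in place of 2-(hydroxycarbamoyl)ethyl on a saturated chain carbon, four bonds along the chain from an aromatic nitrogen. This is a shortening of the same chain, in the same direction as the change that took compound 3 to compound 2, though smaller. For the measured compounds named here, the one measured chain step therefore points to a higher number for compound 4; the expected step is a 4.5-fold higher number from compound 1 to compound 4 (0.66 log units; beyond the scatter), and a limit reading is a real possibility. The estimate for compound 4 in this assay is 100000 nM, with a range of 35000 nM to 300000 nM.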

Compound 4, half-maximal inhibitory concentration: > 150000 nM
Compound 4: only a limit was reported; the forecaster's own chance of this, stated with the estimate: 35%; at least 1.5-fold (0.17 log units) between middle value and limit.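

In this assay, replacing 2-(hydroxycarbamoyl)ethyl with hydroxycarbamoyl on a saturated chain carbon, four bonds along the chain from an aromatic nitrogen, gives an at least 6.8-fold higher number from compound 1 to compound 4 (0.83 log units; beyond the scatter). The only earlier chain step stood on the core of compound 3, so a higher number on shortening the chain is now seen on two cores, and neither of the two chain steps shown goes against it. Compound 4 gives only a limit, so this step is a lower bound and its full size cannot be read: the limit of > 150000 nM in this assay, at which 2 of the 4 values shown sit.

The compounds shown leave open whether a chain longer than that of compound 1 or compound 3 would lower the number further, since the longest chain shown also carries the lowest values in the series. They also leave open whether the hydroxycarbamoyl end itself is needed for the values seen with the longer chain, a question that a carboxylic acid or a primary amide at the same chain end would address on either core.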